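Swapping a chlorinated ring for a phenol on a cyclohexanone bis-arylidene

The source may hold more compounds than are shown below. What is called first, only, known or untested is meant among the compounds shown, and "the series" means these compounds.

Of the compounds shown here, two built on the same core have been tested in an ADME assay on NHDF cells (Homo sapiens) for cytotoxicity, read by MTT assay, with a stated time of 72 h; on this read-out higher numbers stand for weaker inhibition and lower numbers for stronger inhibition. Compound 1 `COc1cc(/C=C2\CCC/C(=C\c3cccc(OC)c3OC)C2=O)cc(OC)c1` gives 13100 nM. Compound 2 `COc1ccc(/C=C2\CCC/C(=C\c3ccccc3Cl)C2=O)cc1OC` gives 21600 nM. Of the two numbers, compound 2 has the higher one, but its gap to compound 1 lies within the scatter of repeated measurements, so the two cannot be told apart on this evidence. Both are weak inhibitors of fibroblast viability.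

Compound 3 `COc1ccc(/C=C2\CCC/C(=C\c3cccc(O)c3)C2=O)cc1OC` has not yet been tested in this assay. It differs from compound 2 in one place: 3-hydroxyphenyl in place of 2-chlorophenyl on a double-bonded chain carbon bound to a double-bonded ring carbon. Among the measured compounds shown here, no measured pair showing this exact swap exists here, so nothing in the data fixes its effect.

Given that both measured numbers sit far from potent territory, the expectation for compound 3 is a value close to that of compound 2, with an estimated step of a 1.2-fold higher number from compound 2 to compound 3 (0.06 log units; within the scatter), which is no more than the scatter, leaning if anything toward a higher number. Compound 3 is therefore estimated at 25000 nM, with a likely range from 8000 nM to 70000 nM.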

Compound 3, half-maximal inhibitory concentration: 6800 nM
Compound 3: middle estimate off by 3.7-fold (0.57 log units), on the high side; measured number below the stated range.
By their numbers in this assay, from the lowest: compounds 3, 1 and 2 (each within the scatter of the next, the first and the last beyond it).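

Among the compounds shown here, putting 3-hydroxyphenyl in place of 2-chlorophenyl on a double-bonded chain carbon bound to a double-bonded ring carbon gives a 3.2-fold lower number from compound 2 to compound 3 (0.50 log units; beyond the scatter) in this assay, and this is the first difference that stands clear of the usual scatter. The position is therefore not indifferent to what it carries, even though the two groups match in their count of heavy atoms and each has one six-membered aromatic ring of carbon only; what differs is one chlorine against one oxygen, and a hydrogen-bond donor and acceptor present only in the entering group. Nothing measured here accounts for the change in number.

Going by these compounds, whether the lower number follows the hydroxyl itself or the place it holds on the ring remains open, and 3-chlorophenyl or 2-hydroxyphenyl at this carbon would separate the two. Also open, on these data alone, is how far the trend would carry to other groups, such as an amine in 3-aminophenyl or a methyl ether in 3-methoxyphenyl.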